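The source may hold more compounds than are shown below. What is called first, only, known or untested is meant among the compounds shown, and "the series" means these compounds.

Measured compounds in an assay on cells for inhibition of Voltage-dependent T-type calcium channel subunit alpha-1G (Homo sapiens), read by patch clamp, tested at 10 uM; on this read-out higher numbers stand for more inhibition at the one concentration tested (going by the name of the read-out) and lower numbers for less inhibition:
Compound 1 `O=C(CC1c2ccccc2N=C(SCCCCCN2CCCC2)N1c1ccc(-c2ccccc2)cc1)NCc1ccc(F)cc1` gives 51.5%.
Compound 2 `O=C(CC1c2ccccc2N=C(SCCCCCN2CCCC2)N1c1ccc(-c2ccc(F)cc2)cc1)NCc1ccc(F)cc1` gives 83.9%.
Compound 3 `O=C(CC1c2ccccc2N=C(SCCCCCN2CCCC2)N1c1ccc(-c2ccc(F)cc2)cc1)NCc1ccccc1` gives 83.9%.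

Compound 2 stands level with compound 3, the two together the highest of the three numbers; the step of a number 32.4 percentage points higher from compound 1 to compound 2 (beyond the scatter) lies beyond the scatter, while the step of no change at the digits printed from compound 2 to compound 3 (within the scatter) lies within it. Compound 4 `O=C(CC1c2ccccc2N=C(SCCCCCN2CCCC2)N1c1ccccc1)NCc1ccc(F)cc1` differs from compound 2 by hydrogen in place of 4-fluorophenyl on an aromatic carbon. No measured step removes this whole ring, but the step of a number 32.4 percentage points higher from compound 1 to compound 2 (beyond the scatter) shows that the fluoro on that ring alone accounts for a large part of the inhibition of compound 2, so removing the ring entirely is expected to give a large drop, a number 43.9 percentage points lower from compound 2 to compound 4 (beyond the scatter). Compound 4 is therefore expected to reach about 40%, with a range from 15% to 65%.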

Compound 4, a percentage reported as inhibition, at one concentration (the size of the read-out at that concentration, not a potency): 60.1%
The estimate for compound 4 lay 20.1 percentage points below the measured number; the range from low to high includes it.
By their numbers in this assay, from the lowest: compounds 1 and 4 (each within the scatter of the next); then compounds 2 and 3 (each within the scatter of the next).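

In this assay, hydrogen in place of 4-fluorophenyl gives a number 23.8 percentage points lower from compound 2 to compound 4 (beyond the scatter) and so shows that this ring with its fluoro adds to inhibition at this position. Hydrogen in place of the unsubstituted phenyl gives a number 8.6 percentage points higher from compound 1 to compound 4 (within the scatter) and so shows that the plain ring brings no gain beyond the scatter over hydrogen, leaving the benefit seen only when the ring carries fluoro. Nothing available explains this dependence on the fluoro. Going by these compounds, whether chloro or methoxy in place of that fluoro would serve equally remains open.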